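The source may report more compounds than this note shows. Statements on the series, on what has been measured and on what is new or still open speak of the compounds shown alone.

Working notes on the series. Of the compounds shown here, three have been measured in a functional assay on MCF7 cells (Homo sapiens) for cytotoxicity, read by MTT assay; on this read-out higher numbers stand for weaker inhibition and lower numbers for stronger inhibition. Compound 1 `COc1ccc(/C=C2\CCC/C(=C\c3ccccc3[N+](=O)[O-])C2=O)cc1` gives 11.2 ug/mL, compound 2 `COc1ccc(/C=C2\CCC/C(=C\c3cccc([N+](=O)[O-])c3)C2=O)cc1` gives 5.71 ug/mL and compound 3 `COc1cccc(/C=C2\CCC/C(=C\c3cccc([N+](=O)[O-])c3)C2=O)c1` gives 4.17 ug/mL. Compound 3 carries the lowest of the three numbers; its gap to compound 2 is within the scatter, while the gap to compound 1 lies beyond it. For the measured compounds named here, the only step that is a single change between measured compounds, a 1.4-fold lower number from compound 2 to compound 3 (0.14 log units; within the scatter), concerns where the methoxy group sits and is within the scatter.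

Compound 4 `COc1cccc(/C=C2\CCC/C(=C\c3cccc([N+](=O)[O-])c3)C2=O)c1OC` differs from compound 3 by methoxy in place of hydrogen on an aromatic carbon. Going by the values given here, no measured step adds a second methoxy group, so nothing among the measured compounds speaks directly to this change; the one step that touches the methoxy-bearing ring was within the scatter. The expectation is therefore a step from compound 3 to compound 4 that stays within the scatter, namely a 1.1-fold higher number from compound 3 to compound 4 (0.03 log units; within the scatter). On that basis compound 4 is estimated at 4.5 ug/mL in this assay, with a range from 2 ug/mL to 10 ug/mL.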

Compound 4, half-maximal inhibitory concentration: 5.14 ug/mL
The estimate for compound 4 lay 1.1-fold (0.06 log units) below the measured number; measured number inside the range.
By their numbers in this assay, from the lowest: compounds 3, 4, 2 and 1 (each within the scatter of the next, the first and the last beyond it).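

In this assay, for the compounds shown here, methoxy in place of hydrogen on an aromatic carbon, ortho to a large group and ortho to a methoxy group, gives a 1.2-fold higher number from compound 3 to compound 4 (0.09 log units; within the scatter) and is the first measured step that adds a group to the methoxy-bearing ring rather than moving one. A second methoxy group at this place therefore leaves the number within the scatter, so this read-out does not separate the one-methoxy and two-methoxy compounds. No measured evidence on the cause of this result is available.

As far as these compounds go, whether an amine, a carboxylic acid or a longer alkoxy chain at this place would also stay within the scatter remains open. The compounds shown also do not tell whether the same methoxy addition would read alike on the core of compound 1.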